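The compounds below may be only part of what the source reports. "The series", "measured", "known", "first", "only" and "open" are said of these compounds alone.

Compound 1 `COc1cccc2c1CCCC2c1c[nH]cn1`: 243 nM in an assay on cell membranes for displacement of a labelled ligand from Adrenergic receptor alpha-1 (Rattus norvegicus); a higher number here means a weaker inhibitor, a lower number a stronger inhibitor
Compound 2 `COc1cccc2c1CCC=C2c1c[nH]cn1`: 2970 nM
Compound 3 `Cc1cccc2c1CCC=C2c1c[nH]cn1`: 992 nM

Compound 2 stands highest of the three numbers in this assay, with compound 3 nearest and compound 1 furthest away. Compound 4 `C1=C(c2c[nH]cn2)c2cccc(OCc3ccccc3)c2CC1` differs from compound 2 by phenyl in place of hydrogen on a saturated chain carbon bound to an oxygen on an aromatic ring; read one bond further out, the methoxy becomes a benzyloxy. For the measured compounds named here, the only measured step that starts from compound 2 is a 3.0-fold lower number from compound 2 to compound 3 (0.48 log units; beyond the scatter), and it replaces the methoxy rather than extending it, so it gives no direct guide. Going by the values given here, no measured pair shows a phenyl added at this place. The expected step is therefore a 1.5-fold lower number from compound 2 to compound 4 (0.17 log units; within the scatter), with no clear direction beyond the scatter. Compound 4 is estimated at 2000 nM, with a range from 500 nM to 8000 nM.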

Compound 4, inhibition constant: 8250 nM
Compound 4: the middle estimate sits 4.1-fold (0.62 log units) below what was measured; the whole stated range lies below it.
By their numbers in this assay, from the lowest: compound 1; then compound 3; then compound 2; then compound 4.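

In this assay, methyl to benzyl, the only change shown that extends the methoxy rather than replacing it, gives a 2.8-fold higher number from compound 2 to compound 4 (0.44 log units; beyond the scatter) as a modest step beyond the scatter. At this place, the number therefore moves the opposite way from a 3.0-fold lower number from compound 2 to compound 3 (0.48 log units; beyond the scatter) in the step that replaces the methoxy. There is no evidence here that explains this direction.

Going by these compounds, what an ethyl or a longer chain on the oxygen would give remains open, as does an amine at the end of such a chain. On these data alone, it is also open whether benzyl in place of methyl would act the same way on the core of compound 1.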